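The compounds below may be only part of what the source reports. "The series", "measured", "known", "first", "only" and "open" are said of these compounds alone.

Measured so far:
compound 1, `COc1cc(C2=NN(C(C)=O)C(c3ccc(F)cc3)O2)cc(OC)c1OC`: 13.3%
compound 2, `COc1cc(C(=O)N/N=C/c2cccc(F)c2)cc(OC)c1OC`: 44.8%

These two compounds were tested in a functional assay on BGC-823 cells (Homo sapiens) for antiproliferative activity, read by MTT assay, tested at 5 uM; on this read-out higher numbers stand for a stronger effect at the one concentration tested and lower numbers for a weaker effect. Compound 1 gives 13.3% in this assay. Compound 2 gives 44.8% in this assay, and the two compounds differ in more than one place, so the two values can only be set side by side: compound 1 stands lowest of the two numbers, with compound 2 higher by a gap beyond the usual scatter.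

Compound 3, `COc1cc(C2=NN(C(C)=O)C(c3cccc(C(F)(F)F)c3)O2)cc(OC)c1OC`, has not yet been measured in this assay. It keeps the core of compound 1 and changes one group: 3-(trifluoromethyl)phenyl in place of 4-fluorophenyl on a saturated ring carbon. Among the measured compounds shown here, no measured pair shows the effect of such a swap on this core. Because compound 1 itself gives only 13.3%, a small step is expected, most likely upward but possibly none beyond the scatter. The step from compound 1 to compound 3 is estimated at a number 6.7 percentage points higher from compound 1 to compound 3 (within the scatter) in this assay. Compound 3 is therefore expected to give about 20%, within a range from 6% to 42%.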

Compound 3, a percentage reported as inhibition, at one concentration (the size of the read-out at that concentration, not a potency): 41.1%
Estimate against measurement, compound 3: 21.1 percentage points below; measured number inside the range.
By their numbers in this assay, from the lowest: compound 1; then compounds 3 and 2 (each within the scatter of the next).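

On the core of compound 1, the saturated ring carbon proves sensitive to the aromatic group it carries: in this assay, placing 3-(trifluoromethyl)phenyl there instead of 4-fluorophenyl gives a number 27.8 percentage points higher from compound 1 to compound 3 (beyond the scatter). Among the compounds shown here, this is the first measured pair on this core, and it shows that the weak effect of compound 1 is not fixed by the core alone, as one change at this carbon moves the read-out beyond the scatter. Nothing available here explains the rise.

The swap changes both the group on the phenyl ring and its printed ring number, so this single step cannot separate the two; a 3-fluorophenyl or 4-(trifluoromethyl)phenyl group would address that question. From the compounds shown here alone, it also remains open how this carbon would respond to a phenyl ring bearing an amine or a carboxylic acid.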